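The source may hold more compounds than are shown below. What is called first, only, known or untested is meant among the compounds shown, and "the series" means these compounds.

Compound 1, `O=[N+]([O-])c1ccc(CN2CCC(n3cc(CC(OCc4cc(-c5ccc(Br)cc5)no4)c4ccc(Br)cc4)nn3)CC2)cc1`, gives in a functional assay on PC-3 cells (Homo sapiens) for cytotoxicity, with a stated time of 48 h (a lower number here means a stronger inhibitor, a higher number a weaker inhibitor), only a limit rather than a number: > 25000 nM.
Compound 2, `O=[N+]([O-])c1ccc(CN2CCC(n3cc(CC(OCc4cc(-c5ccc(F)cc5)no4)c4ccc(Br)cc4)nn3)CC2)cc1`, gives in this assay only a limit as well: > 25000 nM.
Compound 3, `COc1ccc(-c2cc(COC(Cc3cn(C4CCN(Cc5ccc([N+](=O)[O-])cc5)CC4)nn3)c3ccc(Br)cc3)on2)cc1`, gives in this assay 3000 nM.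

Among the compounds with values here, compound 3 therefore stands as the only compound of the three with an actual number; the other two sit at the limit of > 25000 nM in this assay, at which 2 of the 3 values shown sit. The two readable steps both lead to compound 3: an at least 8.3-fold lower number from compound 1 to compound 3 (0.92 log units; beyond the scatter) and an at least 8.3-fold lower number from compound 2 to compound 3 (0.92 log units; beyond the scatter). The step between the two limits, a step that the two limits leave unreadable from compound 1 to compound 2, says nothing about size.

Compound 4, `N#Cc1ccc(-c2cc(COC(Cc3cn(C4CCN(Cc5ccc([N+](=O)[O-])cc5)CC4)nn3)c3ccc(Br)cc3)on2)cc1`, differs from compound 3 by cyano in place of methoxy on an aromatic carbon. Within the data shown here, no measured step covers cyano at this place. What the measured steps do show is that bromo and fluoro at this position both leave the compound at the assay limit, and only methoxy gives a number. Cyano is a third replacement with no measured parallel, so the expectation rests only on the fact that two of three substituents tried here gave no measurable activity.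

Compound 4 is therefore expected to be weaker than compound 3, with a fair chance of returning to the limit, and the expected step is a 5.0-fold higher number from compound 3 to compound 4 (0.70 log units; beyond the scatter). The estimate for compound 4 in this assay is 15000 nM, within a range from 3000 nM to 50000 nM.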

Compound 4, half-maximal inhibitory concentration: 2000 nM
The estimate for compound 4 lay 7.5-fold (0.88 log units) above the measured number; the whole stated range lies above it.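

Within the data shown here, compound 4 shows that methoxy is not the only group at this place that gives a number in this assay, since the step to cyano is a 1.5-fold lower number from compound 3 to compound 4 (0.18 log units; within the scatter), so the two groups cannot be told apart here. The same cyano group separates clearly from both halogens, with an at least 12-fold lower number from compound 2 to compound 4 (1.09 log units; beyond the scatter) and an at least 12-fold lower number from compound 1 to compound 4 (1.09 log units; beyond the scatter), and so the earlier contrast between methoxy and the halogens now extends to a second group that shares no atom type with them beyond carbon. Compound 1 and compound 2 stay at a limit and not at a number, so the true size of these steps remains unknown, and the four compounds now divide evenly at this place, with 4-methoxyphenyl and 4-cyanophenyl giving numbers and the bromo and fluoro compounds giving none: the limit of > 25000 nM in this assay, at which 2 of the 4 values shown sit.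

The step from compound 1 to compound 2 cannot be read, so nothing separates bromo from fluoro. On these data alone, how an amine, a carboxylic acid, a hydroxyl or a longer chain such as ethoxy would behave on this aromatic carbon remains open, as does whether any group here could go well beyond compound 3 and compound 4.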